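Nitro for bromo: working notes on compound 4

This account rests on a few compounds, and the source may have more. Where it says the series, first, only, none or still open, it means among the compounds named here.

Measured so far:
compound 1 `N#CCC(=O)N/N=C(/CBr)c1ccc(Br)cc1`: 10000 nM
compound 2 `N#CCC1=NN=C(c2ccc(Br)cc2)C(CC(=O)c2ccc(Br)cc2)O1`: 22100 nM
compound 3 `N#CCC1=NN=C(c2ccc(Br)cc2)C(CC(=O)c2ccc([N+](=O)[O-])cc2)O1`: 23000 nM

In a functional assay on NCI-H460 cells (Homo sapiens) for inhibition, read by sulforhodamine B assay, with a stated time of 48 h (a lower number here means a stronger inhibitor of growth, a higher number a weaker inhibitor of growth), compound 1 gives the lowest of the three numbers. The values of compound 2 and compound 3 both lie higher, each by a margin just beyond the usual scatter.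

The unmeasured compound 4 `N#CCC(=O)N/N=C(/CBr)c1ccc([N+](=O)[O-])cc1` keeps the core of compound 1 and changes one group: nitro in place of bromo on an aromatic carbon. This is nitro in place of bromo on an aromatic carbon, para to a large group.

One measured step makes the same exchange: a 1.0-fold higher number from compound 2 to compound 3 (0.02 log units; within the scatter). It sits on a different core from compound 1, and a single pair is thin evidence, so the transfer is uncertain. Among the compounds with values here, the data hold no pair on the core of compound 1 itself. Within the data shown here, with that one step as the only guide, no change beyond the scatter is expected in this assay, in either direction. The estimated step is no change at the digits printed from compound 1 to compound 4 (within the scatter). Compound 4 is expected at 10000 nM, with an estimated range of 5000 nM to 22000 nM.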

Compound 4, concentration for 50% growth inhibition: 10300 nM
The estimate for compound 4 lay 1.0-fold (0.01 log units) below the measured number, and the stated range covers the measured number.
By their numbers in this assay, from the lowest: compounds 1 and 4 (each within the scatter of the next); then compounds 2 and 3 (each within the scatter of the next).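

On the aromatic carbon para to a large group, on the core of compound 1, nitro in place of bromo gives a 1.0-fold higher number from compound 1 to compound 4 (0.01 log units; within the scatter) in this assay. The earlier compounds held this exchange on a single core only; it now stands on two cores, and the two steps agree: the same change on two cores in this assay, a 1.0-fold higher number (0.02 log units; within the scatter) from compound 2 to compound 3 and a 1.0-fold higher number (0.01 log units; within the scatter) from compound 1 to compound 4, 1.0-fold (0.00 log units) apart, within the scatter of two such steps

At this position on the core of compound 1, exchanging 1 heavy atom for 3 heavy atoms and 0 hydrogen-bond acceptors for 2 hydrogen-bond acceptors leaves the number within the scatter, a reading that rests on this one pair and that no compound shown goes against.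

The compounds shown compare only bromo and nitro at this position, so the effect of an amine, a carboxylic acid or a plain hydrogen there remains open. Also open, from the compounds shown here alone, is how this assay responds to changes elsewhere on the core of compound 1, such as a longer chain carrying the nitrile.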